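The compounds below may be only part of what the source reports. "The series", "measured", "known", "first", "only" and "open" are said of these compounds alone.

Measured so far in an assay on HEK293 cells for inhibition of sodium channel protein type 10 subunit alpha (Homo sapiens), read by fluorescence; on this read-out lower numbers stand for stronger inhibition and higher numbers for weaker inhibition:
- compound 1, `COc1ccc(Cl)c(-c2ccc(NC(=O)c3ccnn3C)nc2N)c1`, gives 700 nM
- compound 2, `Cn1nccc1C(=O)Nc1ccc(-c2ccccc2Cl)c(N)n1`, gives 4900 nM
- compound 3, `Cn1nccc1C(=O)Nc1ccc(-c2ccccc2OC(F)(F)F)c(N)n1`, gives 2400 nM

Among these three numbers compound 3 holds the second highest. Its nearest neighbour is compound 2, reached by the step of a 2.0-fold lower number from compound 2 to compound 3 (0.31 log units; beyond the scatter); further away lies compound 1, and the step of a 7.0-fold higher number from compound 1 to compound 2 (0.85 log units; beyond the scatter) shows how much of that distance comes from the methoxy group alone.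

Compound 4, `Nc1nc(NC(=O)c2ccccc2)ccc1-c1ccccc1OC(F)(F)F`, has not been measured. It differs from compound 3 in one place: phenyl in place of 1-methyl-1H-pyrazol-5-yl on a carbonyl carbon. The two steps measured so far both change the substituted benzene ring that hangs from the shared core, not the amide side. For the measured compounds named here, neither of them speaks to an exchange of the ring on the carbonyl carbon, so there is no measured step that bears directly on this change. With nothing to lean on, the fair expectation for this assay is a step of no clear size, leaning neither strongly up nor down, and the range around it must be wide. Compound 4 is therefore estimated at 2800 nM, between 700 nM and 11000 nM, which means an expected step of a 1.2-fold higher number from compound 3 to compound 4 (0.07 log units; within the scatter).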

Compound 4, half-maximal inhibitory concentration: 3200 nM
The estimate for compound 4 lay 1.1-fold (0.06 log units) below the measured number; measured number inside the range.
By their numbers in this assay, from the lowest: compound 1; then compounds 3, 4 and 2 (each within the scatter of the next, the first and the last beyond it).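

In this assay, this first measured exchange on the amide side of the shared core gives a 1.3-fold higher number from compound 3 to compound 4 (0.12 log units; within the scatter), so compound 3 and compound 4 cannot be told apart by this read-out. A five-membered aromatic ring with hetero atoms is replaced on this carbonyl carbon by a six-membered aromatic ring of carbon only, with no hydrogen-bond acceptors, and the result remains within the scatter, whereas the earlier exchange on the benzene ring, a 7.0-fold higher number from compound 1 to compound 2 (0.85 log units; beyond the scatter), lies beyond it. No measurement shown here explains why the pair reads alike.

A single pair cannot show how tolerant this position is in general, and a pyridine ring, a saturated ring such as cyclohexyl, or a ring carrying an amine or a carboxylic acid on the carbonyl carbon could give a quite different number. From the compounds shown here alone, it also remains open whether phenyl in place of 1-methyl-1H-pyrazol-5-yl would read the same when the other ring carries the methoxy and chloro groups of compound 1, which gives 700 nM.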